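Pyridinylmethyl in place of chlorophenyl on the ring nitrogen

The source may report more compounds than this note shows. Statements on the series, on what has been measured and on what is new or still open speak of the compounds shown alone.

Compound 1 has the structure `Nc1ccccc1NC(=O)c1ccc(CSC(=S)N2CCN(c3ccc(Cl)cc3)CC2)cc1`. In a functional assay on MGC-803 cells (Homo sapiens) for antiproliferative activity, read by CCK-8 assay, with a stated time of 72 h, tested at 8 uM (a higher number here means a stronger effect of the compound at the concentration tested, a lower number a weaker effect), compound 1 gives 17.2%, the lowest of the two numbers measured. The nearest neighbour is compound 2, with the structure `Nc1ccccc1NC(=O)c1ccc(CSC(=S)N2CCCc3ccccc32)cc1`; in this assay compound 2 gives 87.5%, a value beyond the scatter above that of compound 1. Among the measured compounds shown here, the two share the same core, but no single-point step between measured compounds is available, so the gap between them cannot be tied to one change.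

Compound 3, with the structure `Nc1ccccc1NC(=O)c1ccc(CSC(=S)N2CCN(Cc3ccncc3)CC2)cc1`, has not yet been measured in this assay. It differs from compound 1 in one place: (pyridin-4-yl)methyl in place of 4-chlorophenyl on an amine nitrogen in a ring The group that leaves and the group that enters are each counted at the same number of heavy atoms, each with one six-membered aromatic ring, but the entering group carries one hydrogen-bond acceptor and a ring hetero atom where the leaving group has none.

For compound 3 the expected step in this assay is a number 12.8 percentage points higher from compound 1 to compound 3 (beyond the scatter), a modest rise that may still fall within the scatter. Compound 3 is therefore estimated to give 30%, between 10% and 65%.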

Compound 3, a percentage reported as inhibition, at one concentration (the size of the read-out at that concentration, not a potency): 79.3%
Compound 3: the middle estimate sits 49.3 percentage points below what was measured, and the stated range ends below it.
By their numbers in this assay, from the lowest: compound 1; then compounds 3 and 2 (each within the scatter of the next).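

In this assay, among the compounds shown here, replacing 4-chlorophenyl with (pyridin-4-yl)methyl on the amine nitrogen in the six-membered non-aromatic ring with 2 nitrogen gives a number 62.1 percentage points higher from compound 1 to compound 3 (beyond the scatter), the first step here that can be tied to one place, and it shows that the group on this nitrogen can by itself separate a weak read-out from a strong one at the concentration tested. The low number of compound 1 is thus not set by the rest of its structure, which compound 3 keeps unchanged, and the heavy-atom count does not separate the two groups, as each is counted at the same number and each carries one six-membered aromatic ring. The step nevertheless combines the loss of chlorine, the ring nitrogen and the one-carbon link, and nothing available here explains the rise or assigns it to any of these.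

The compounds shown leave open which of these differences carries the step, a question that benzyl, 4-chlorobenzyl or pyridin-4-yl on the same nitrogen could help to answer. They also leave open whether (pyridin-3-yl)methyl or (pyridin-2-yl)methyl would behave like the (pyridin-4-yl)methyl group.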